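The source may hold more compounds than are shown below. What is called first, only, known or untested is meant among the compounds shown, and "the series" means these compounds.

Measured compounds:
Compound 1, `Cc1c(-c2csc(NC(=S)Nc3ccccc3)n2)c(=O)n(-c2ccccc2)n1C`, gives 8350 nM in a functional assay on HepG2 cells (Homo sapiens) for cytotoxicity, read by sulforhodamine B assay, with a stated time of 72 h; on this read-out higher numbers stand for weaker inhibition and lower numbers for stronger inhibition.
Compound 2, `Cc1c(-c2csc(/N=c3\sc(-c4ccccc4)nn3-c3ccccc3)n2)c(=O)n(-c2ccccc2)n1C`, gives > 100000 nM in this assay; this is a limit of the assay, not a number.
Compound 3, `CC(=O)c1nn(-c2ccc(Cl)cc2)/c(=N/c2nc(-c3c(C)n(C)n(-c4ccccc4)c3=O)cs2)s1`, gives > 100000 nM in this assay; this too is a limit of the assay, not a number.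

Compound 3 thus stands at a limit in this assay, and no number is known for it. Two of the three values shown sit at the limit of > 100000 nM in this assay, at which 2 of the 3 values shown sit. Among the compounds with values here, no step between measured compounds that differ in one place is available.

Compound 4, `COc1ccc(-n2nc(C(C)=O)s/c2=N\c2nc(-c3c(C)n(C)n(-c4ccccc4)c3=O)cs2)cc1`, differs from compound 3 by methoxy in place of chloro on an aromatic carbon. With compound 3 sitting at the limit of > 100000 nM in this assay, at which 2 of the 3 values shown sit, there is nothing to suggest that this change would bring the value into the measurable range. The step expected in this assay is a number no higher from compound 3 to compound 4 (the limit leaves the size open), none beyond the usual scatter. Compound 4 is accordingly expected at 100000 nM, with a range from 30000 nM to 300000 nM, and most likely again reported only as a limit.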

Compound 4, half-maximal inhibitory concentration: 41300 nM
The estimate for compound 4 lay 2.4-fold (0.38 log units) above the measured number, and the stated range covers the measured number.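

Replacing 4-chlorophenyl with 4-methoxyphenyl gives, in this assay, an at least 2.4-fold lower number from compound 3 to compound 4 (0.38 log units; beyond the scatter). Within the data shown here, this shows that a single change at this position can bring a compound from the limit into the measurable range, which the earlier compounds could not show, as no pair among them differed in one place. The size of the step nevertheless remains open, since compound 3 has only a limit and no number: the limit of > 100000 nM in this assay, at which 2 of the 4 values shown sit.

The compounds shown leave open whether the lower number follows from the presence of methoxy or from the loss of chloro. They also leave open how an amine, a hydroxyl or a longer ether such as ethoxy would read at this position, and whether methoxy would give a similar step in another part of the molecule.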